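Aryl swap on the aromatic nitrogen of compound 2

The compounds below may be only part of what the source reports. "The series", "measured", "known", "first", "only" and "open" are said of these compounds alone.

compound 1 `Cc1ccc(-n2nncc2CN2C(=O)C3(C(C#N)=C(N)Oc4c3c3nc5ccccc5nc3c3ccccc43)c3ccccc32)cc1Cl` — > 50000 nM
compound 2 `CC(=O)Nc1ccc(-n2nncc2CN2C(=O)C3(C(C#N)=C(N)Oc4c(N)cc5nc6ccccc6nc5c43)c3ccccc32)cc1` — > 50000 nM

Both readings come from a functional assay on HCT-116 cells (Homo sapiens) for antiproliferative activity, read by MTT assay, with a stated time of 48 h; on this read-out higher numbers stand for weaker inhibition and lower numbers for stronger inhibition. For compound 1 the reading is a limit of the assay, not a number. For the measured compounds named here, for compound 2 the reading is likewise a limit and not a number, so compound 2 stands at the limit with no numerical value to rank it; the only other value shown is also a limit (the limit of > 50000 nM in this assay, at which 2 of the 2 values shown sit).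

Compound 3 `N#CC1=C(N)Oc2c(N)cc3nc4ccccc4nc3c2C12C(=O)N(Cc1cnnn1-c1cc(Cl)ccc1Cl)c1ccccc12` is the next to be measured. Its difference from compound 2: 2,5-dichlorophenyl in place of 4-acetamidophenyl on an aromatic nitrogen.

Going by the values given here, no step between measured compounds is available, so the size of the step in this assay cannot be calibrated from the series itself. The expectation is that compound 3 also returns a limit rather than a number. Compound 3 is estimated at 60000 nM, within 20000 nM to 200000 nM. That corresponds to an expected step that the limit leaves unreadable from compound 2 to compound 3, that is none beyond the scatter.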

Compound 3, half-maximal inhibitory concentration: > 50000 nM
Compound 3 gave a limit, no number; the forecaster's own chance of this, stated with the estimate: 80%; the middle value does not contradict the limit.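

For the compounds shown here, compound 2 and compound 3 both give a limit of the assay rather than a number, so no step between them can be read. The compounds shown leave open whether any group on the aromatic nitrogen gives a measurable reading on this core.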